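Fluoro for Chloro on the Fused Ring of Compound 2

This account rests on a few compounds, and the source may have more. Where it says the series, first, only, none or still open, it means among the compounds named here.

Measured so far:
Compound 1 `Cc1ccc2nc(Nc3nc(Nc4ccc(S(N)(=O)=O)cc4)ncc3F)sc2c1` gives 6390 nM.
Compound 2 `Cc1cnc(Nc2ccc(S(C)(=O)=O)cc2)nc1Nc1nc2ccc(Cl)cc2s1` gives 5900 nM.
Compound 3 `Cc1cnc(Nc2ccc(Cl)cc2)nc1Nc1nc2ccccc2s1` gives > 50000 nM.

All three were tested in a functional assay on MDA-MB-231 cells (Homo sapiens) for antiproliferative activity, read by MTT assay, with a stated time of 48 h; on this read-out lower numbers stand for stronger inhibition and higher numbers for weaker inhibition. Among the compounds with values here, compound 3 returned only a limit of the assay, not a number, and this is the one value of the three that sits at the limit of > 50000 nM in this assay, at which 1 of the 3 values shown sits. Of the two numbers that remain, compound 2 stands at one end, but compound 1 is so close that the gap between them lies within the usual scatter of repeated runs, so no order between compound 2 and compound 1 can be read from them.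

Compound 4 `Cc1cnc(Nc2ccc(S(C)(=O)=O)cc2)nc1Nc1nc2ccc(F)cc2s1` differs from compound 2 in a single place: fluoro in place of chloro on an aromatic carbon, on the six-membered carbon ring of the fused system, meta to a fused ring and para to a fused ring. Within the data shown here, no pair among the measured compounds shows this same swap, so no measured step is available to guide the expectation. The change is small in size, and the expected step in this assay is therefore none beyond the scatter, with a slight lean toward a weaker number. Compound 4 is estimated at 7500 nM, within a range from 3000 nM to 18000 nM, which corresponds to an expected step of a 1.3-fold higher number from compound 2 to compound 4 (0.10 log units; within the scatter).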

Compound 4, half-maximal inhibitory concentration: > 50000 nM
Compound 4 was reported as a limit; the forecaster's own chance of this, stated with the estimate: 5%; at least 6.6-fold (0.82 log units) between middle value and limit.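

In this assay compound 4 gives > 50000 nM, which is a limit of the assay and not a number. Fluoro in place of chloro on this aromatic carbon, meta to a fused ring and para to a fused ring, amounts to an at least 8.4-fold higher number from compound 2 to compound 4 (0.92 log units; beyond the scatter), so this position is not indifferent to the change, and the earlier compounds, which held no pair differing here, could not show this. The step gives only a lower bound on the size of the change, since compound 4 now stands among the values that yield no number: the limit of > 50000 nM in this assay, at which 2 of the 4 values shown sit.

What bromo, methyl or methoxy would do on this same carbon remains open, so the compounds shown cannot tell whether chloro is specifically favoured or fluoro specifically disfavoured. Also open, from the compounds shown here alone, are how far compound 4 lies beyond its limit and whether the same swap would have a comparable effect in a compound carrying an amine or a carboxylic acid in place of the methylsulfonyl group.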